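This account rests on a few compounds, and the source may have more. Where it says the series, first, only, none or still open, it means among the compounds named here.

Compounds measured in an assay on CHO cells for displacement of a labelled ligand from Alpha-1D adrenergic receptor (Homo sapiens); on this read-out lower numbers stand for stronger inhibition and higher numbers for weaker inhibition:
- compound 1 `COc1cccc(OC)c1OCCNCCOc1ccccc1OCc1ccccc1`: 0.0676 nM
- compound 2 `COc1cccc(OC)c1OCCNCCOc1ccccc1OCc1cccc(Cl)c1`: 0.0501 nM
- compound 3 `COc1cccc(OC)c1OCCNCCOc1ccccc1OCc1ccccc1C`: 0.126 nM

Among these three, compound 3 gives the highest number in this assay. Its nearest neighbour is compound 1, and a 1.9-fold higher number from compound 1 to compound 3 (0.27 log units; within the scatter) lies within the scatter, so the two cannot be told apart; the gap to compound 2 is larger, since a 2.5-fold higher number from compound 2 to compound 3 (0.40 log units; beyond the scatter) reaches beyond the scatter, though only modestly.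

Compound 4 `COc1cccc(OC)c1OCCNCCOc1ccccc1OCc1ccc(C)cc1` is not yet measured. It differs from compound 3 by 4-methylphenyl in place of 2-methylphenyl on a saturated chain carbon bound to an oxygen on an aromatic ring — the two have the same atoms, joined differently. For the measured compounds named here, no measured pair compares two positions of the same methyl group, so the bearing of the measured steps is indirect. The step of a 1.9-fold higher number from compound 1 to compound 3 (0.27 log units; within the scatter), which adds the methyl, stays within the scatter, and a 1.3-fold lower number from compound 1 to compound 2 (0.13 log units; within the scatter) shows that a chloro in place of hydrogen on the same aromatic carbon also stays within the scatter. All three measured numbers sit within a narrow band. On this basis no step beyond the scatter is expected from compound 3 to compound 4 in this assay, with the estimate a 1.4-fold lower number from compound 3 to compound 4 (0.15 log units; within the scatter) leaning slightly toward a lower number, back toward compound 1.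

Compound 4 is therefore expected to give about 0.09 nM in this assay, within a range from 0.04 nM to 0.2 nM.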

Compound 4, inhibition constant: 0.0631 nM
Estimate against measurement, compound 4: 1.4-fold (0.15 log units) above, within the range that was stated.
By their numbers in this assay, from the lowest: compounds 2, 4, 1 and 3 (each within the scatter of the next, the first and the last beyond it).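

For the compounds shown here, this pair is the first to compare two placements of the same methyl group at this place, on a saturated chain carbon bound to an oxygen on an aromatic ring: in this assay, the change to 4-methylphenyl from 2-methylphenyl gives a 2.0-fold lower number from compound 3 to compound 4 (0.30 log units; within the scatter), so the two isomers cannot be told apart. Compound 4 also cannot be told apart from its unsubstituted parent, as a 1.1-fold lower number from compound 1 to compound 4 (0.03 log units; within the scatter) shows, or from the chloro analogue, as a 1.3-fold higher number from compound 2 to compound 4 (0.10 log units; within the scatter) shows, although the 2-methylphenyl compound did stand apart from that analogue, with a 2.5-fold higher number from compound 2 to compound 3 (0.40 log units; beyond the scatter) reaching modestly beyond the scatter. No measurement offered here accounts for these numbers or explains that one separated pair.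

The compounds shown carry only hydrogen, methyl or chloro on this phenyl ring, so it remains open whether a methoxy group, a carboxylic acid or an amine there would keep the number in the same narrow band. They also leave open whether the 2-methylphenyl and 4-methylphenyl groups would stay indistinguishable on a different core or in a different read-out.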